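Chloropyridinyl sulfonamide variants on the bromonaphthylmethyl triazole core

The source may report more compounds than this note shows. Statements on the series, on what has been measured and on what is new or still open speak of the compounds shown alone.

Compound 2 `O=S(=O)(CSc1nnc(Br)n1Cc1ccc(Br)c2ccccc12)Nc1ccccc1` gives 15800 nM in an assay on HEK293 cells for inhibition of solute carrier family 22 member 12 (Homo sapiens) (a lower number here means a stronger inhibitor, a higher number a weaker inhibitor), the highest of the three numbers measured. Compound 1 `O=C(O)CSc1nnc(Br)n1Cc1ccc(Br)c2ccccc12` gives 94 nM, the step of a 170-fold higher number from compound 1 to compound 2 (2.23 log units; beyond the scatter) being the largest in the series. Compound 3 `O=S(=O)(CSc1nnc(Br)n1Cc1ccc(Br)c2ccccc12)Nc1ccc(Cl)nc1` gives 1940 nM, reached by an 8.1-fold lower number from compound 2 to compound 3 (0.91 log units; beyond the scatter). Compound 4 `O=S(=O)(CSc1nnc(Br)n1Cc1ccc(Br)c2ccccc12)Nc1cccnc1Cl` is not yet measured; it differs from compound 2 by 2-chloropyridin-3-yl in place of phenyl on a sulfonamide nitrogen. Among the compounds with values here, the one step that bears on it, the same exchange with a different chloropyridinyl, lowered the number from compound 2 to compound 3 by a modest margin, so a lowering of similar or somewhat smaller size is expected here, with the step from compound 2 to compound 4 estimated at a 4.0-fold lower number from compound 2 to compound 4 (0.60 log units; beyond the scatter). Compound 4 is therefore expected to give about 4000 nM in this assay, within 1500 nM to 12000 nM.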

Compound 4, half-maximal inhibitory concentration: 5100 nM
Estimate against measurement, compound 4: 1.3-fold (0.11 log units) below; the range from low to high includes it.
By their numbers in this assay, from the lowest: compound 1; then compound 3; then compound 4; then compound 2.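

In this assay the 2-chloropyridin-3-yl group also improves on phenyl on the sulfonamide nitrogen, with a 3.1-fold lower number from compound 2 to compound 4 (0.49 log units; beyond the scatter), so the lowering is not confined to the 6-chloropyridin-3-yl group of compound 3. The two chloropyridinyl groups are not interchangeable, with a 2.6-fold higher number from compound 3 to compound 4 (0.42 log units; beyond the scatter), a gap beyond the scatter. No available evidence explains this difference. Open, on these data alone, is whether a pyridin-3-yl group without chlorine keeps the lowering. Also open, as far as these compounds go, is what a methoxy group in place of the chlorine, or a carboxylic acid on that ring, would give.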